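This account rests on a few compounds, and the source may have more. Where it says the series, first, only, none or still open, it means among the compounds named here.

Working notes on the series. All four compounds share one core and differ only in the aryl group on the carbonyl carbon. Compound 1 `COc1cc(-c2nnc3n2NC(c2ccco2)C(C(=O)c2ccc(F)c(F)c2)S3)cc(OC)c1OC` carries 3,4-difluorophenyl there, and in a functional assay on HepG2 cells (Homo sapiens) for cytotoxicity, read by MTT assay, with a stated time of 48 h (on this read-out lower numbers stand for stronger inhibition and higher numbers for weaker inhibition), compound 1 gives 52400 nM. Compound 2 `COc1cc(-c2nnc3n2NC(c2ccco2)C(C(=O)c2ccc(Br)cc2)S3)cc(OC)c1OC` carries 4-bromophenyl; in this assay compound 2 returns only a limit, > 100000 nM. Compound 3 `COc1cc(-c2nnc3n2NC(c2ccco2)C(C(=O)c2ccc(O)cc2)S3)cc(OC)c1OC` carries 4-hydroxyphenyl; in this assay compound 3 likewise returns only a limit, > 100000 nM. Compound 3 thus stands at the limit of > 100000 nM in this assay, at which 2 of the 3 values shown sit, and no number separates it from compound 2. The readable steps are an at least 1.9-fold higher number from compound 1 to compound 2 (0.28 log units; that floor lies within the scatter) and an at least 1.9-fold higher number from compound 1 to compound 3 (0.28 log units; that floor lies within the scatter), while a step that the two limits leave unreadable from compound 2 to compound 3.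

Compound 4 `COc1cc(-c2nnc3n2NC(c2ccco2)C(C(=O)c2ccc(F)cc2)S3)cc(OC)c1OC` differs from compound 3 by fluoro in place of hydroxy on an aromatic carbon. Within the data shown here, no measured step covers this exact change. The nearest comparisons are the two steps from compound 1, together with compound 1 itself, which with 3,4-difluorophenyl gives 52400 nM in this assay. The expectation for compound 4 in this assay is therefore a value at or near the limit, the step of an at least 1.1-fold lower number from compound 3 to compound 4 (0.04 log units; that floor lies within the scatter) being of unreadable size. Compound 4 is estimated at 90000 nM, within 40000 nM to 200000 nM.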

Compound 4, half-maximal inhibitory concentration: > 100000 nM
Compound 4 ended at the assay's limit; the forecaster's own chance of this, stated with the estimate: 55%; at least 1.1-fold (0.04 log units) between middle value and limit.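

Fluoro on the aromatic carbon para to a large group gives no number in this assay, and compound 4 returns only a limit of the assay. With fluoro, the series now has three different single groups at this place, bromo, hydroxy and fluoro, that all end at the same point: the limit of > 100000 nM in this assay, at which 3 of the 4 values shown sit.

The steps among compound 2, compound 3 and compound 4 cannot be read, as all three values are limits, so the change from hydroxy to fluoro has no measurable size here. Among these compounds, the one readable new step, hydrogen in place of fluoro on an aromatic carbon, is an at least 1.9-fold higher number from compound 1 to compound 4 (0.28 log units; that floor lies within the scatter), so it does not establish that the second fluoro of compound 1 matters.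

As far as these compounds go, how far compound 2, compound 3 and compound 4 lie past the limit stays open, and so does any order among them. Also open, from the compounds shown here alone, is whether an amine, a carboxylic acid or a methoxy group at this place would give a number in this assay, and whether a second substituent other than fluoro on this ring would do so.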